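Phenyl in place of dichlorophenyl on a piperazine nitrogen

A few compounds are considered here, and "the series" means these few. Any claim that something is new, unique, unknown or untested is made for them only; others in the source may bear on it.

Compound 2 `Cc1ccc(-[n+]2noc([O-])c2CN2CCN(c3cccc(Cl)c3Cl)CC2)cc1` was tested in an ADME assay on HEL cells (Homo sapiens) for cytotoxicity (on this read-out lower numbers stand for higher toxicity in this test and higher numbers for lower toxicity in this test), and gave 20 ug/mL, the lowest of the two numbers available. Compound 1 `Cc1ccc(-[n+]2noc([O-])c2CN2CCCCC2)cc1` gave 100 ug/mL in this assay, a figure clearly higher than that of compound 2. Compound 3 `[O-]c1on[n+](-c2ccc(Cc3ccc(-[n+]4noc([O-])c4CN4CCN(c5ccccc5)CC4)cc3)cc2)c1CN1CCN(c2ccccc2)CC1` reached only a limit of the test, >= 20 ug/mL, in this assay. The next compound, compound 4 `Cc1ccc(-[n+]2noc([O-])c2CN2CCN(c3ccccc3)CC2)cc1`, differs from compound 2 in one place: phenyl in place of 2,3-dichlorophenyl on an amine nitrogen in a ring. Among the measured compounds shown here, no measured pair shows this change, so its effect is judged from the spread of the values shown, among which the only limit is the limit of >= 20 ug/mL in this assay, at which 1 of the 3 values shown sits. Compound 4 is expected to give a higher number than compound 2, an estimated step of a 2.5-fold higher number from compound 2 to compound 4 (0.40 log units; beyond the scatter) that would lie beyond the usual scatter. Its value in this assay for compound 4 is estimated at 50 ug/mL, between 20 ug/mL and 100 ug/mL.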

Compound 4, minimum cytotoxic concentration: 100 ug/mL
The estimate for compound 4 lay 2.0-fold (0.30 log units) below the measured number, and the stated range covers the measured number.
By their numbers in this assay, from the lowest: compound 2; then compounds 1 and 4 (each within the scatter of the next).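

In this assay, the change gives a 5.0-fold higher number from compound 2 to compound 4 (0.70 log units; beyond the scatter). Among the compounds shown here, this is the first measured step at this place, on an amine nitrogen in a ring, and it shows that the number for this read-out responds to the aryl group carried there: with the same core, the 2,3-dichlorophenyl of compound 2 and the phenyl of compound 4 are clearly apart. Nothing measured here gives a reason for the step.

Going by these compounds, whether a single chlorine would carry the whole step remains open. So does how a methoxy group or a carboxylic acid on the phenyl would read in this assay.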